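The source may hold more compounds than are shown below. What is called first, only, known or untested is meant among the compounds shown, and "the series" means these compounds.

Compound 1, `CC#CCn1c(N2CCC[C@@H](N)C2)cc(=O)n(Cc2cc(Br)cc(C(=O)O)c2)c1=O`, compound 3, `CC#CCn1c(N2CCC[C@@H](N)C2)cc(=O)n(Cc2cc(C(=O)O)ccc2F)c1=O`, and compound 2, `CC#CCn1c(N2CCC[C@@H](N)C2)cc(=O)n(Cc2cc(C(=O)OC)ccc2F)c1=O`, share one core and are told apart only by the group on the saturated chain carbon bound to an aromatic nitrogen. In an assay on isolated protein for inhibition of Dipeptidyl peptidase 9 (Homo sapiens), read by fluorescence, with stated times of 15 min and 20 min (a higher number here means a weaker inhibitor, a lower number a stronger inhibitor), compound 1 gives > 100 nM, which is a limit of the assay and not a number. In this assay compound 3 likewise gives > 100 nM, again a limit. Compound 2 gives > 100 nM in this assay, once more a limit. Because of the limit of > 100 nM in this assay, at which 3 of the 3 values shown sit, neither of the measured steps can be read: the change methyl in place of hydrogen on an oxygen next to a carbonyl group gives a step that the two limits leave unreadable from compound 3 to compound 2, and the change of core 3-bromo-5-carboxyphenyl in place of 5-carboxy-2-fluorophenyl on a saturated chain carbon bound to an aromatic nitrogen gives a step that the two limits leave unreadable from compound 1 to compound 3.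

Compound 4, `CC#CCn1c(N2CCC[C@@H](N)C2)cc(=O)n(Cc2cc(Br)cc(C(=O)OC)c2)c1=O`, has not been measured in this assay. Going by the values given here, it differs from compound 1 by methyl in place of hydrogen on an oxygen next to a carbonyl group, which is the same change as the one from compound 3 to compound 2, made at the same place, on an oxygen next to a carbonyl group whose other neighbour is the carbonyl carbon. Because compound 1 gives only the limit > 100 nM and because the step from compound 3 to compound 2 is a step that the two limits leave unreadable from compound 3 to compound 2, no size can be taken from the measured pair, and compound 4 is expected to move by about a step that the limit leaves unreadable from compound 1 to compound 4, which is no readable shift at all. Compound 4 is therefore estimated to give 300 nM in this assay, most likely reported again only as a limit, with a range from 100 nM to 3000 nM.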

Compound 4, half-maximal inhibitory concentration: > 100 nM
Compound 4: only a limit was reported; the forecaster's own chance of this, stated with the estimate: 85%; the middle value lies beyond the limit too.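

In this assay compound 4 gives > 100 nM, which is again a limit of the assay and not a number. Going by these compounds alone, the comparison of compound 4 with compound 1 therefore yields no new step that can be read, because of this shared limit: the limit of > 100 nM in this assay, at which 4 of the 4 values shown sit. The compounds shown leave open how strongly compounds 1, 2, 3 and 4 actually inhibit, and whether carboxy to methoxycarbonyl changes that at all.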